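Two Fluorines in Place of Two Chlorines on the Ketone

The compounds below may be only part of what the source reports. "The series", "measured", "known", "first", "only" and "open" are said of these compounds alone.

Measured in a functional assay on MDA-MB-435 cells (Homo sapiens) for inhibition, read by sulforhodamine B assay, with a stated time of 48 h; a lower number here means a stronger inhibitor of growth, a higher number a weaker inhibitor of growth:
Compound 1, `COc1ccc(-c2cc(/C=C/C(=O)c3ccc(N)cc3)[nH]n2)cc1`: 2240 nM
Compound 2, `COc1cc(-c2cc(/C=C/C(=O)c3ccc(Cl)c(Cl)c3)[nH]n2)cc(OC)c1OC`: 5650 nM

Compound 2 holds the higher of the two numbers, that is, it is the weaker growth inhibitor; compound 1 sits at a lower value, and that gap lies beyond the usual scatter. Compound 3, `COc1cc(-c2cc(/C=C/C(=O)c3ccc(F)c(F)c3)[nH]n2)cc(OC)c1OC`, has not yet been tested. It differs from compound 2 in one place: 3,4-difluorophenyl in place of 3,4-dichlorophenyl on a carbonyl carbon. For the measured compounds named here, no measured pair shows this exact change, so the step from compound 2 to compound 3 is expected to be modest, estimated as a 1.4-fold higher number from compound 2 to compound 3 (0.15 log units; within the scatter), leaning toward a higher number. Compound 3 is therefore expected to give about 8000 nM in this assay, estimated to fall between 2500 nM and 25000 nM.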

Compound 3, concentration for 50% growth inhibition: 2880 nM
Estimate against measurement, compound 3: 2.8-fold (0.44 log units) above; the range from low to high includes it.
By their numbers in this assay, from the lowest: compounds 1, 3 and 2 (each within the scatter of the next, the first and the last beyond it).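

In this assay, for the compounds shown here, there is a 2.0-fold lower number from compound 2 to compound 3 (0.29 log units; within the scatter) and this is the first comparison here that changes only one place. On this carbonyl carbon, 3,4-difluorophenyl and 3,4-dichlorophenyl therefore cannot be told apart, so swapping one pair of halogens for the other gives no clear change in growth inhibition. Nothing available explains this result.

Still open, as far as these compounds go, is whether the halogens are needed at all. An unsubstituted phenyl or a phenyl carrying a carboxylic acid on this carbonyl carbon could show whether this position responds to a larger change.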